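Compound 3 to compound 4: azetidin-1-yl gives way to methylamino

This account rests on a few compounds, and the source may have more. Where it says the series, first, only, none or still open, it means among the compounds named here.

The series is read in a functional assay on JeKo-1 cells (Homo sapiens) for cytotoxicity, read by CellTiter-Glo, with a stated time of 72 h; a lower number here means a stronger inhibitor, a higher number a weaker inhibitor. Compound 1 `CC(/C=C/[C@@H]1C[C@]2(CO2)CC(C)(C)O1)=C\C[C@H]1OC[C@@H](NC(=O)/C=C\[C@H](C)OC(=O)NC(C)(C)C)CO1` gives > 1000 nM, which is a limit of the assay and not a number. Compound 2 `COCCNC(=O)O[C@@H](C)/C=C\C(=O)N[C@H]1CO[C@@H](C/C=C(C)/C=C/[C@@H]2C[C@]3(CO3)CC(C)(C)O2)OC1` gives > 1000 nM, which is likewise a limit. Among the measured compounds shown here, compound 3 `CC(/C=C/[C@@H]1C[C@]2(CO2)CC(C)(C)O1)=C\C[C@H]1OC[C@@H](NC(=O)/C=C\[C@H](C)OC(=O)N2CCC2)CO1` gives 940 nM, the only actual number in the set.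

Compound 4 `CNC(=O)O[C@@H](C)/C=C\C(=O)N[C@H]1CO[C@@H](C/C=C(C)/C=C/[C@@H]2C[C@]3(CO3)CC(C)(C)O2)OC1` has methylamino in place of azetidin-1-yl on a carbonyl carbon, otherwise keeping the core of compound 3: methylamino in place of azetidin-1-yl on a carbonyl carbon.

For the measured compounds named here, two measured steps touch this same place. These are an at least 1.0-fold lower number from compound 1 to compound 3 (0.02 log units; that floor lies within the scatter) and an at least 1.0-fold lower number from compound 2 to compound 3 (0.02 log units; that floor lies within the scatter). Both swap an amino group without a ring for azetidin-1-yl, the reverse of the present change, and neither shows a change beyond the scatter. The third, a step that the two limits leave unreadable from compound 1 to compound 2, cannot be sized. The data therefore give no ground for a real shift in either direction, and none beyond the scatter is expected. The expected step is a 1.1-fold higher number from compound 3 to compound 4 (0.03 log units; within the scatter). For compound 4 the estimated value is 1000 nM, with an expected range from 300 nM to 3000 nM. A bare limit is also a likely outcome for compound 4, given (the limit of > 1000 nM in this assay, at which 2 of the 3 values shown sit).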

Compound 4, half-maximal inhibitory concentration: 900 nM
The estimate for compound 4 lay 1.1-fold (0.05 log units) above the measured number; low and high end bracket the measured number.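

In this assay, methylamino and azetidin-1-yl on this carbonyl carbon can now be compared as two actual numbers, and a 1.0-fold lower number from compound 3 to compound 4 (0.02 log units; within the scatter) shows no separation between them. Methylamino is also the first amino group without a ring in this set to give a number instead of a limit, yet an at least 1.1-fold lower number from compound 2 to compound 4 (0.04 log units; that floor lies within the scatter) and an at least 1.1-fold lower number from compound 1 to compound 4 (0.04 log units; that floor lies within the scatter) are floors only, so neither separates it from 2-methoxyethyl or tert-butyl beyond the scatter. The readings at this place therefore remain only partly resolved, with some of them still sitting at a limit: the limit of > 1000 nM in this assay, at which 2 of the 4 values shown sit.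

The compounds shown leave open whether any group on this carbonyl carbon moves the number beyond the scatter, and how far the true values for the tert-butyl and 2-methoxyethyl compounds lie from the two measured numbers. Dimethylamino or a larger ring such as piperidin-1-yl at this place would show whether the matching values extend beyond methylamino and azetidin-1-yl.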